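The source may hold more compounds than are shown below. What is called first, only, known or untested is meant among the compounds shown, and "the series" means these compounds.

Measured so far:
- compound 1 `Cc1nc(NCCNS(C)(=O)=O)nc(N[C@@H]2C[C@H](CO)[C@@H](O)[C@H]2O)c1-c1nc2ccccc2s1` gives > 25000 nM
- compound 2 `Cc1nc(NCCC(F)(F)F)nc(N[C@@H]2C[C@H](CO)[C@@H](O)[C@H]2O)c1-c1nc2ccccc2s1` gives 9000 nM
- compound 3 `Cc1nc(Nc2nccs2)nc(N[C@@H]2C[C@H](CO)[C@@H](O)[C@H]2O)c1-c1nc2ccccc2s1` gives 15000 nM

The value of compound 1 in an ADME assay on cells (Homo sapiens) for cytotoxicity, read by polymerase chain reaction, with a stated time of 3 days (a higher number here means that more compound is tolerated, a lower number that less compound is tolerated), is a limit of the assay, not a number. Compound 3 and compound 2 give numbers that lie within the scatter of each other, as a 1.7-fold higher number from compound 2 to compound 3 (0.22 log units; within the scatter) shows. Compound 4 `Cc1nc(NCc2ccccc2)nc(N[C@@H]2C[C@H](CO)[C@@H](O)[C@H]2O)c1-c1nc2ccccc2s1` has not been measured; it differs from compound 3 by benzyl in place of 1,3-thiazol-2-yl on a nitrogen on an aromatic ring. Within the data shown here, no measured step swaps one ring for another on that nitrogen. The nearest comparisons are an at least 2.7-fold lower number from compound 1 to compound 2 (0.44 log units; beyond the scatter) and an at least 1.6-fold lower number from compound 1 to compound 3 (0.22 log units; that floor lies within the scatter), which alter the same nitrogen's substituent, and only one of them fell beyond the scatter. A step within the scatter is therefore expected, a 1.4-fold lower number from compound 3 to compound 4 (0.13 log units; within the scatter). Compound 4 is estimated at 11000 nM, in a range from 4000 nM to 30000 nM.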

Compound 4, half-maximal cytotoxic concentration: 9000 nM
Estimate against measurement, compound 4: 1.2-fold (0.09 log units) above; the range from low to high includes it.
By their numbers in this assay, from the lowest: compounds 2, 4 and 3 (each within the scatter of the next). At a limit, above all of these: compound 1.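

In this assay, a carbon-only ring on this nitrogen behaves like the earlier groups: benzyl in place of 1,3-thiazol-2-yl gives a 1.7-fold lower number from compound 3 to compound 4 (0.22 log units; within the scatter), and phenyl in place of 2,2,2-trifluoroethyl gives no change at the digits printed from compound 2 to compound 4 (within the scatter). Hetero atoms in the ring are therefore not needed to keep the number in this range. Compound 1 gives a limit rather than a number, so an at least 2.7-fold lower number from compound 1 to compound 4 (0.44 log units; beyond the scatter) is only a floor: the limit of > 25000 nM in this assay, at which 1 of the 4 values shown sits.

Still open, on these data alone, is whether an amine or a carboxylic acid on the chain at this nitrogen would also reach that limit, as the methanesulfonamido chain does. A longer chain ending in phenyl is equally unresolved.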